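The source may hold more compounds than are shown below. What is called first, only, known or untested is meant among the compounds shown, and "the series" means these compounds.

Measured compounds in a functional assay (aorta) with Rattus norvegicus as the target; a higher number here means that more compound is needed for the effect, a lower number that less compound is needed:
- compound 1 `CC1(C)CC(NC(=O)Nc2ccccc2)c2cc(F)ccc2O1` gives 17100 nM
- compound 2 `COc1ccc(NC(=O)NC2CC(C)(C)Oc3ccc(F)cc32)cc1` gives 15500 nM
- compound 3 `COc1ccc(NC(=O)NC2CC(C)(C)Oc3ccc(Cl)cc32)cc1` reaches only the limit > 30000 nM

Compound 2 and compound 1 sit within the scatter of each other in this assay, as the step of a 1.1-fold lower number from compound 1 to compound 2 (0.04 log units; within the scatter) shows. Compound 3 gives only a limit of the assay (the limit of > 30000 nM in this assay, at which 1 of the 3 values shown sits). Compound 4 `Cc1ccc(NC(=O)NC2CC(C)(C)Oc3ccc(F)cc32)cc1` is not yet measured; it differs from compound 2 by methyl in place of methoxy on an aromatic carbon. The closest measured step is the one at the same position, a 1.1-fold lower number from compound 1 to compound 2 (0.04 log units; within the scatter), which lay within the scatter; the step of an at least 1.9-fold higher number from compound 2 to compound 3 (0.28 log units; that floor lies within the scatter) concerns another position. A step of no more than the scatter is therefore expected for compound 4, a 1.0-fold higher number from compound 2 to compound 4 (0.01 log units; within the scatter). Compound 4 is estimated at 16000 nM, within 8000 nM to 32000 nM, in this assay.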

Compound 4, half-maximal effective concentration: > 30000 nM
Compound 4: a limit, no number; the forecaster's own chance of this, stated with the estimate: 20%; at least 1.8-fold (0.27 log units) between middle value and limit.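

Hydrogen and methoxy at this position had given measurable numbers, but methyl is the first group here to carry the fluoro compounds to the assay's limit: the limit of > 30000 nM in this assay, at which 2 of the 4 values shown sit. In this assay, the change from 4-methoxyphenyl to 4-methylphenyl gives an at least 1.9-fold higher number from compound 2 to compound 4 (0.28 log units; that floor lies within the scatter), and adding methyl in place of hydrogen gives an at least 1.7-fold higher number from compound 1 to compound 4 (0.24 log units; that floor lies within the scatter). Both are floors, so the position is not shown to be insensitive to every group, but no real size can be given for either step.

Going by these compounds, the true size of these steps stays open. So does whether an amine or a carboxylic acid at this position would give a lower number than hydrogen or methoxy.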